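Aryl swaps on the alkyne arm: outlook for compound 4

The compounds below may be only part of what the source reports. "The series", "measured", "known", "first", "only" and "open" are said of these compounds alone.

Measured compounds: compound 1 `COC(=O)c1sc2cc(C#Cc3ccccn3)cnc2c1N`, 37400 nM; compound 2 `COC(=O)c1sc2cc(C#Cc3cccc(N)c3)cnc2c1N`, 10800 nM. Compound 3 `COC(=O)c1sc2cc(C#Cc3cccnc3)cnc2c1N` gives only a limit in a functional assay on MCF7 cells (Homo sapiens) for inhibition, read by sulforhodamine B assay, with a stated time of 48 h (a lower number here means a stronger inhibitor of growth, a higher number a weaker inhibitor of growth), > 150000 nM, as noted in the limit of > 150000 nM in this assay, at which 1 of the 3 values shown sits.

Compound 1 stands highest of the two numbers shown; its nearest neighbour is compound 2, reached by a 3.5-fold lower number from compound 1 to compound 2 (0.54 log units; beyond the scatter). The step to compound 3, an at least 4.0-fold higher number from compound 1 to compound 3 (0.60 log units; beyond the scatter), runs the other way, and an at least 13-fold higher number from compound 2 to compound 3 (1.14 log units; beyond the scatter) is large.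

Compound 4 `COC(=O)c1sc2cc(C#Cc3ccsc3)cnc2c1N` differs from compound 1 by thiophen-3-yl in place of pyridin-2-yl on a triple-bonded carbon. Both measured steps change the same group and both exceed the scatter, in opposite directions, so the direction for a thiophen-3-yl is open. The expected step is a 1.1-fold higher number from compound 1 to compound 4 (0.03 log units; within the scatter), and compound 4 is estimated at 40000 nM, within 12000 nM to 150000 nM.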

Compound 4, concentration for 50% growth inhibition: 27700 nM
Beside the measured number, compound 4's estimate is 1.4-fold (0.16 log units) above it; low and high end bracket the measured number.
By their numbers in this assay, from the lowest: compound 2; then compounds 4 and 1 (each within the scatter of the next). At a limit, above all of these: compound 3.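

Thiophen-3-yl on the triple-bonded carbon is not told apart from pyridin-2-yl in this assay, with a 1.4-fold lower number from compound 1 to compound 4 (0.13 log units; within the scatter), so a five-membered aromatic ring without nitrogen can take this place with no change beyond the scatter. Against the other two arms the same ring gives a 2.6-fold higher number from compound 2 to compound 4 (0.41 log units; beyond the scatter) and an at least 5.4-fold lower number from compound 3 to compound 4 (0.73 log units; beyond the scatter). The second of these steps rests on a limit for compound 3: the limit of > 150000 nM in this assay, at which 1 of the 4 values shown sits.

Open, as far as these compounds go, is where a plain phenyl would fall on this triple-bonded carbon, which would show how much of the 3-aminophenyl result goes with its amine.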